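Methoxy removal on the benzylamine arm of the shared core

The compounds below may be only part of what the source reports. "The series", "measured", "known", "first", "only" and "open" are said of these compounds alone.

Measured so far:
- compound 1, `[SeH]c1nc(NCc2ccccc2)c2cccnc2n1`; in a functional assay on MCF7 cells (Homo sapiens) for cytotoxicity, read by MTT assay, with a stated time of 72 h (on this read-out lower numbers stand for higher toxicity in this test and higher numbers for lower toxicity in this test), compound 1 gives > 100000 nM, which is a limit of the assay, not a number.
- compound 2, `COc1ccc(CNc2nc(SC)nc3ncccc23)cc1`; in this assay compound 2 gives > 100000 nM, again a limit and not a number.

Among the compounds with values here, compound 2 therefore stands nowhere on a scale of numbers: it sits at the top limit of this assay , and the only other value shown sits at the same limit (the limit of > 100000 nM in this assay, at which 2 of the 2 values shown sit). Within the data shown here, no step between measured compounds can be given, as compound 1 and compound 2 differ in more than one place.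

Compound 3, `CSc1nc(NCc2ccccc2)c2cccnc2n1`, is obtained from compound 2 by hydrogen in place of methoxy on an aromatic carbon of a six-membered aromatic ring of carbon only, para to a large group. Among the measured compounds shown here, with no measured step to lean on, no change beyond the scatter is expected in this assay ; the expected step that the limit leaves unreadable from compound 2 to compound 3 is taken as flat. Compound 3 is thus estimated at 150000 nM, within 30000 nM to 600000 nM, most likely reported as a limit again.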

Compound 3, concentration lethal to 50% of the cells: > 100000 nM
Compound 3: a limit, no number; the forecaster's own chance of this, stated with the estimate: 80%; the middle value is on the limit's open side.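

No step can be read from compound 2 to compound 3 or from compound 1 to compound 3, as each result in this assay is a limit and not a number: the limit of > 100000 nM in this assay, at which 3 of the 3 values shown sit.

The compounds shown leave open whether methoxy on the benzylamine arm has any effect in this assay, and whether any change on the shared core gives a readable number.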